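Swapping an Aromatic Ring for a Non-Aromatic One

This account rests on a few compounds, and the source may have more. Where it says the series, first, only, none or still open, it means among the compounds named here.

Within the data shown here, compound 2 `C[C@@H](O[C@H]1CN2C(=O)C=C(c3ccc(CO)cc3)CC2[C@@H]1c1ccc(F)cc1)c1cc(C(F)(F)F)cc(C(F)(F)F)c1` gives 23 nM in an assay on CHO cells for displacement of a labelled ligand from Substance-P receptor (Homo sapiens), in the presence of a further agent that is not named here (on this read-out higher numbers stand for weaker inhibition and lower numbers for stronger inhibition), the lowest of the three numbers measured so far. Compound 3 `CCc1noc(C2=CC(=O)N3C[C@H](O[C@H](C)c4cc(C(F)(F)F)cc(C(F)(F)F)c4)[C@@H](c4ccc(F)cc4)C3C2)n1` gives 27 nM, and compound 1 `C[C@@H](O[C@H]1CN2C(=O)C=C(c3ccc(C#N)cc3)CC2[C@@H]1c1ccc(F)cc1)c1cc(C(F)(F)F)cc(C(F)(F)F)c1` gives 53 nM. The step of a 1.2-fold higher number from compound 2 to compound 3 (0.07 log units; within the scatter) lies within the scatter, whereas the step of a 2.3-fold lower number from compound 1 to compound 2 (0.36 log units; beyond the scatter) is modest but beyond it.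

Compound 4 `C[C@@H](O[C@H]1CN2C(=O)C=C(C3=CCOCC3)CC2[C@@H]1c1ccc(F)cc1)c1cc(C(F)(F)F)cc(C(F)(F)F)c1` is compound 2 with one change: a group of 6 heavy atoms (5 carbon, 1 oxygen; one six-membered non-aromatic ring with 1 hetero atom) in place of a group of 8 heavy atoms (7 carbon, 1 oxygen; one six-membered aromatic ring of carbon only), on a double-bonded ring carbon The steps already seen at this position are the ones that bear on it. Both the step of a 2.0-fold lower number from compound 1 to compound 3 (0.29 log units; within the scatter) and the step of a 1.2-fold higher number from compound 2 to compound 3 (0.07 log units; within the scatter) show that exchanging one ring for another here has so far shifted the number only a little. Among the measured compounds shown here, none of those exchanges, however, removed the aromatic ring or the hydrogen-bond donor, so no measured step covers this change, and the expectation leans toward a modest weakening. Compound 4 is therefore expected to show a 2.0-fold higher number from compound 2 to compound 4 (0.29 log units; within the scatter), close to the edge of the scatter. The estimate for compound 4 is 45 nM, with a range from 15 nM to 140 nM.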

Compound 4, half-maximal inhibitory concentration: 9.6 nM
Estimate against measurement, compound 4: 4.7-fold (0.67 log units) above, outside the stated range (below it).
By their numbers in this assay, from the lowest: compound 4; then compounds 2, 3 and 1 (each within the scatter of the next, the first and the last beyond it).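

At this position in the shared core, an aromatic ring and a hydrogen-bond donor are not needed for a low number in this assay: the non-aromatic ring that enters gives a 2.4-fold lower number from compound 2 to compound 4 (0.38 log units; beyond the scatter) and also a 2.8-fold lower number from compound 3 to compound 4 (0.45 log units; beyond the scatter). The widest gap is a 5.5-fold lower number from compound 1 to compound 4 (0.74 log units; beyond the scatter), and all three steps lie beyond the scatter, whereas the two earlier ring exchanges at this carbon stayed within it. Nothing measured here accounts for this gain.

Still open, as far as these compounds go, is which part of the entering group matters, the ring oxygen or the double bond in the ring. A cyclohexenyl group, with carbon in place of that oxygen, a tetrahydropyranyl group, without the double bond, or a piperidine ring carrying an amine nitrogen would each separate these features.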